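From Fluoro to Methoxy on a Shared Core

A few compounds are considered here, and "the series" means these few. Any claim that something is new, unique, unknown or untested is made for them only; others in the source may bear on it.

compound 1 `O[C@@H]1[C@@H](O)[C@H](Oc2ccc3ccccc3c2)OC[C@H]1F`: 37 uM
compound 2 `CO[C@H]1[C@H](Oc2ccc3ccccc3c2)OC[C@@H](O)[C@@H]1O`: 127 uM
compound 3 `O[C@H]1[C@H](Oc2ccc3ccccc3c2)OC[C@@H](O)[C@@H]1F`: 94 uM

In a functional assay on HCC70 cells (Homo sapiens) for antiproliferative activity, read by crystal violet staining, with a stated time of 96 h (on this read-out higher numbers stand for an effect only at larger amounts of compound and lower numbers for an effect already at smaller amounts), compound 3 gives 94 uM. For the measured compounds named here, compound 2 gives 127 uM, and that number lies within the scatter of the one for compound 3. Compound 1 gives 37 uM. Going by the values given here, its number is lower than the one for compound 3, and the gap between the two lies beyond the scatter.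

Compound 4 `CO[C@@H]1[C@@H](O)[C@H](Oc2ccc3ccccc3c2)OC[C@H]1O` has not yet been measured. It differs from compound 3 in one place: methoxy in place of fluoro on a saturated ring carbon. This is methoxy in place of fluoro on a saturated ring carbon, next to two ring atoms that each bear a hydroxy group.

Among the compounds with values here, no measured pair shows this exchange directly, so the expectation rests on indirect evidence. Compound 2 also carries a methoxy group, and its value of 127 uM lies within the scatter of the value for compound 3. Compound 1 also carries fluoro, yet its value of 37 uM lies apart from that of compound 3, so fluoro alone does not fix the number.

In this assay no step beyond the scatter is therefore expected. The expected change is a 1.2-fold higher number from compound 3 to compound 4 (0.07 log units; within the scatter). For compound 4 the estimated value is 110 uM, with an expected range from 50 uM to 240 uM.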

Compound 4, concentration for half-maximal effect: 145 uM
Estimate against measurement, compound 4: 1.3-fold (0.12 log units) below, and the stated range covers the measured number.
By their numbers in this assay, from the lowest: compound 1; then compounds 3, 2 and 4 (each within the scatter of the next).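

In this assay, for the compounds shown here, this pair gives the direct reading of the exchange that the earlier compounds could not supply: a 1.5-fold higher number from compound 3 to compound 4 (0.19 log units; within the scatter), so methoxy in place of fluoro on this saturated ring carbon does not separate the two compounds. At this place, next to two ring atoms that each bear a hydroxy group and two ring bonds from the ring atom that bears a large group, the number therefore stays within the scatter when fluoro leaves and methoxy enters, even though the entering group brings one hydrogen-bond acceptor and the leaving group brings none. No measurement shown here offers an explanation for this outcome.

The compounds shown leave open whether a group of another kind at this position, such as an amine, a carboxylic acid or a longer chain, would give a number beyond the scatter of the value for compound 3. They also leave open whether the same exchange would read the same way at any other place on the shared core.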